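The source may hold more compounds than are shown below. What is called first, only, known or untested is meant among the compounds shown, and "the series" means these compounds.

Measured compounds:
compound 1 `CCc1nc2sccn2c1/C=N/OCc1ccc(Cl)c(Cl)c1` — 2600 nM
compound 2 `Clc1ccc(CO/N=C/c2c(-c3ccc4ccccc4c3)nc3occn23)cc1Cl` — 370 nM

In an assay on HepG2 cells for agonist activity at nuclear receptor subfamily 1 group I member 3 (Homo sapiens), read by a luciferase reporter, with a stated time of 23 h (on this read-out higher numbers stand for an effect only at larger amounts of compound and lower numbers for an effect already at smaller amounts), compound 1 gives 2600 nM, the highest of the two numbers; compound 2 gives 370 nM, lower by a margin beyond the scatter. Compound 3 `N#Cc1ccc(-c2nc3sccn3c2/C=N/OCc2ccc(Cl)c(Cl)c2)cc1` is not yet measured; it carries 4-cyanophenyl in place of ethyl on an aromatic carbon. For the measured compounds named here, no single-change step between measured compounds is available to calibrate this. An aryl group on a related core is seen in compound 2, whose 370 nM is the lower number, so the step is expected to be downward and beyond the scatter: a 4.3-fold lower number from compound 1 to compound 3 (0.64 log units; beyond the scatter). Compound 3 is estimated at 600 nM, with a range from 200 nM to 2000 nM.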

Compound 3, half-maximal effective concentration: 3400 nM
Compound 3: the middle estimate sits 5.7-fold (0.75 log units) below what was measured, and the stated range ends below it.
By their numbers in this assay, from the lowest: compound 2; then compounds 1 and 3 (each within the scatter of the next).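

In this assay, for the compounds shown here, the first step that can be read at this position is a 1.3-fold higher number from compound 1 to compound 3 (0.12 log units; within the scatter) for 4-cyanophenyl in place of ethyl on the aromatic carbon of the shared core. This position therefore carries a six-membered aromatic ring bearing a nitrile, and the number stays level with that of the ethyl compound. No measurement shown bears on this outcome.

Going by these compounds, it remains open whether a plain phenyl, a longer chain, an amine or a carboxylic acid at this carbon would read differently. Also open, on these data alone, is whether the nitrile itself matters here.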